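Thallium-flux notes on the aryl ether acid series

The source may report more compounds than this note shows. Statements on the series, on what has been measured and on what is new or still open speak of the compounds shown alone.

In an assay on HEK293 cells for positive allosteric modulation of metabotropic glutamate receptor 3 (Rattus norvegicus), read by thallium flux, with a stated time of 2.5 min (a higher number here means a larger maximal response, a lower number a smaller maximal response), compound 1, structure `Cc1c(OCCCCOCOc2ccc(C(=O)O)cc2)ccc(C(=O)CC2CCCC2)c1O`, gives 46.9%, the highest of the three numbers measured. Compound 2, structure `Cc1c(OCCCCOc2ccc(C(=O)O)cc2)ccc(C(=O)CC(C)C)c1C`, gives 16.6%, and compound 3, structure `Cc1c(OCCCCOc2cccc(C(=O)O)c2)ccc(C(=O)CC(C)C)c1C`, gives 18.3%; both lie beyond the scatter below compound 1, but each differs from it in more than one place, so their gaps to compound 1 are read only as the two values show. Going by the values given here, the single one-place step measured, a number 1.7 percentage points higher from compound 2 to compound 3 (within the scatter), moves the carboxyl from 4-carboxyphenyl to 3-carboxyphenyl on an oxygen on a saturated carbon and stays within the scatter.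

Compound 4, structure `Cc1ccc(C(=O)O)cc1OCCCCOc1ccc(C(=O)CC2CCCC2)c(O)c1C`, is to be measured in this assay. Relative to compound 1 the change is 5-carboxy-2-methylphenyl in place of (4-carboxyphenoxy)methyl on an oxygen on a saturated carbon. Among the compounds with values here, the measured step from compound 2 to compound 3 bears on it only in part: it shows that shifting the carboxyl around its ring did not move the maximal response, but no measured pair covers the loss of the (4-carboxyphenoxy)methyl unit or the entry of 5-carboxy-2-methylphenyl. The expected step is therefore small and uncertain, a number 8.9 percentage points lower from compound 1 to compound 4 (within the scatter), leaning slightly downward but plausibly within the scatter. Compound 4 is estimated at 38%, with a range from 18% to 55%.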

Compound 4, largest response reached (reported as percent of maximum), in percent of the reference or control that the assay uses: 26.9%
For compound 4 the middle estimate is 11.1 percentage points above the measured one, and the stated range covers the measured number.
By their numbers in this assay, from the lowest: compounds 2, 3 and 4 (each within the scatter of the next, the first and the last beyond it); then compound 1.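

Going by these compounds alone, at this place, on an oxygen on a saturated carbon, replacing (4-carboxyphenoxy)methyl with 5-carboxy-2-methylphenyl gives the first one-place change to leave the scatter in this assay, with a number 20 percentage points lower from compound 1 to compound 4 (beyond the scatter) as a modest step, whereas the only earlier step, a number 1.7 percentage points higher from compound 2 to compound 3 (within the scatter) and stayed within it. With the core of compound 1 kept and a carboxyl present in both groups, the maximal response in this series is shown to depend on the group that carries the carboxyl, not merely on the presence of a carboxyl, though this rests on a single pair. No measurement of any property bears on this step, so the drop stands without an explanation.

The swap changes several features at once, and the compounds shown do not separate the loss of the (4-carboxyphenoxy)methyl unit from the added ring methyl or the altered placement of the carboxylic acid. Also open, from the compounds shown here alone, is whether a tetrazole or a primary amide in place of the carboxylic acid would keep the maximal response of compound 1.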